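This account rests on a few compounds, and the source may have more. Where it says the series, first, only, none or still open, it means among the compounds named here.

Three compounds share one core and were tested in a functional assay on KB-V1 cells (Homo sapiens) for cytotoxicity, read by MTT assay, with a stated time of 72 h; a lower number here means a stronger inhibitor, a higher number a weaker inhibitor. Compound 1 `CNC(=S)N/N=C1\C(=O)Nc2ccccc21` gives 19400 nM, compound 2 `COc1ccccc1NC(=S)N/N=C1\C(=O)Nc2ccccc21` gives 2690 nM, and compound 3 `O=C1Nc2ccccc2/C1=N/NC(=S)Nc1ccc(Cl)cc1` gives 4990 nM. Compound 3 thus stands second highest of the three numbers, though its gap to compound 2 is within the scatter, while the step of a 3.9-fold lower number from compound 1 to compound 3 (0.59 log units; beyond the scatter) lies beyond it. Compound 4 `CCCC1CCC(c2ccc(NC(=S)N/N=C3\C(=O)Nc4ccccc43)cc2)CC1` differs from compound 3 in one place: 4-propylcyclohexyl in place of chloro on an aromatic carbon. Within the data shown here, no measured step changes a group on that aromatic carbon; the only measured step, a 3.9-fold lower number from compound 1 to compound 3 (0.59 log units; beyond the scatter), concerns the amide-type nitrogen and so bears only loosely on this change. A small step is therefore expected, a 1.4-fold lower number from compound 3 to compound 4 (0.15 log units; within the scatter). Compound 4 is estimated at 3500 nM, with a range from 1200 nM to 10000 nM.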

Compound 4, half-maximal inhibitory concentration: 11000 nM
Beside the measured number, compound 4's estimate is 3.1-fold (0.50 log units) below it; measured number outside the range, above it.
By their numbers in this assay, from the lowest: compounds 2 and 3 (each within the scatter of the next); then compounds 4 and 1 (each within the scatter of the next).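

Replacing chloro with 4-propylcyclohexyl on this aromatic carbon gives a 2.2-fold higher number from compound 3 to compound 4 (0.34 log units; beyond the scatter). Among these compounds, the only earlier step changed the group on the amide-type nitrogen, so this is the first sign that the group at this aromatic position also matters, and here the much larger group gives the weaker result. No measurement here accounts for this rise.

Going by these compounds, with only chloro and 4-propylcyclohexyl compared at this position, it remains open whether the ring or the propyl chain drives the change. A plain cyclohexyl, a short ethyl chain or an amine there could help separate these possibilities.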